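Nitro in Place of Bromo on the Anilide Ring

This account rests on a few compounds, and the source may have more. Where it says the series, first, only, none or still open, it means among the compounds named here.

Measured compounds:
compound 1 `COc1cc2c(cc1OC)C(CC(=O)Nc1ccccc1)CC2`: 37.5%
compound 2 `COc1cc2c(cc1OC)C(CC(=O)Nc1ccc(Br)cc1)CC2`: 40.6%

In a functional assay on the whole organism (strain Wistar) for inhibition, with Rattus norvegicus as the target, read by paw edema, with a stated time of 4 h, at a dose of 100 mg/kg (a higher number here means more inhibition at the dose given (going by the name of the read-out), a lower number less inhibition), compound 2 holds the upper of the two numbers, yet the step of a number 3.1 percentage points higher from compound 1 to compound 2 (within the scatter) is within the scatter, so compound 1 and compound 2 are not separable. Compound 3 `COc1cc2c(cc1OC)C(CC(=O)Nc1ccc([N+](=O)[O-])cc1)CC2` differs from compound 2 by nitro in place of bromo on an aromatic carbon. Within the data shown here, the only step bearing on this place, a number 3.1 percentage points higher from compound 1 to compound 2 (within the scatter), was small, so no step beyond the scatter is expected in this assay. Compound 3 is estimated at 40% (range 28% to 52%), an expected step of a number 0.6 percentage points lower from compound 2 to compound 3 (within the scatter).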

Compound 3, a percentage reported as inhibition, in the whole organism at one dose (the size of the read-out at that dose, not a potency): 37.5%
Beside the measured number, compound 3's estimate is 2.5 percentage points above it; the measured number falls inside the stated range.
By their numbers in this assay, from the lowest: compounds 1, 3 and 2 (each within the scatter of the next).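

Nitro in place of bromo gave a number 3.1 percentage points lower from compound 2 to compound 3 (within the scatter) in this assay, and nitro in place of hydrogen gave no change at the digits printed from compound 1 to compound 3 (within the scatter). This place on the anilide ring, para to a large group, has therefore taken bromo and nitro, as well as plain hydrogen, without a step beyond the scatter. Nothing available explains this result.

Going by these compounds, whether an amine or a carboxylic acid on this aromatic carbon would give a step beyond the scatter remains open. So does the effect of any change to the shared core.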